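Aryl group swap at the para position of the anilide

This account rests on a few compounds, and the source may have more. Where it says the series, first, only, none or still open, it means among the compounds named here.

Measured compounds:
Compound 1 `CC(C)C[C@H](N)CN(C(=O)[C@@H]1C[C@H]1c1ccccc1)c1ccc(-c2cccnc2)cc1` gives 10000 nM in a functional assay for agonist activity at G protein-coupled receptor 88 (Homo sapiens), read by HTRF and cAMP accumulation; on this read-out higher numbers stand for an effect only at larger amounts of compound and lower numbers for an effect already at smaller amounts.
Compound 2 `CC(C)C[C@H](N)CN(C(=O)[C@@H]1C[C@H]1c1ccccc1)c1ccc(C2=CCCCCC2)cc1` gives 2100 nM in this assay.
Compound 3 `CC(C)C[C@H](N)CN(C(=O)[C@@H]1C[C@H]1c1ccccc1)c1ccc(-c2cccc(F)c2)cc1` gives 2100 nM in this assay.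

Compound 3 stands level with compound 2, and the two together sit at the lowest numbers of the three; compound 1 lies furthest away, with a 4.8-fold lower number from compound 1 to compound 3 (0.68 log units; beyond the scatter) separating it from compound 3. The step from compound 2 to compound 3 shows no change at the digits printed from compound 2 to compound 3 (within the scatter).

Compound 4 `CC(C)C[C@H](N)CN(C(=O)[C@@H]1C[C@H]1c1ccccc1)c1ccc(-c2ccccc2Cl)cc1` differs from compound 3 in one place: 2-chlorophenyl in place of 3-fluorophenyl on an aromatic carbon. For the measured compounds named here, no measured step exchanges one halogenated phenyl group for another, so the two steps that touch compound 3 bear only loosely on it. Replacing pyridin-3-yl with 3-fluorophenyl gave a 4.8-fold lower number from compound 1 to compound 3 (0.68 log units; beyond the scatter), while replacing cyclohept-1-en-1-yl with 3-fluorophenyl gave no change at the digits printed from compound 2 to compound 3 (within the scatter); a six-membered carbon ring in this place has thus either kept or lowered the number, never raised it beyond the scatter. For compound 4 the expectation is therefore a step of a 1.2-fold higher number from compound 3 to compound 4 (0.08 log units; within the scatter) in this assay, that is, no change beyond the scatter. Compound 4 is estimated at 2500 nM, within the range 800 nM to 8000 nM.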

Compound 4, half-maximal effective concentration: 3800 nM
Beside the measured number, compound 4's estimate is 1.5-fold (0.18 log units) below it; the measured number falls inside the stated range.
By their numbers in this assay, from the lowest: compounds 2, 3 and 4 (each within the scatter of the next); then compound 1.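

In this assay, 2-chlorophenyl gives a 1.8-fold higher number from compound 3 to compound 4 (0.26 log units; within the scatter) and a 1.8-fold higher number from compound 2 to compound 4 (0.26 log units; within the scatter), so at this place on the shared core it stands with 3-fluorophenyl and cyclohept-1-en-1-yl, with nothing to separate the three. It also gives a 2.6-fold lower number from compound 1 to compound 4 (0.42 log units; beyond the scatter), which makes it a third group with a ring of carbon only to stand apart from pyridin-3-yl, and none of the four compounds goes against this pattern. The halogen and its place on the phenyl ring change together in this one step, so their contributions cannot be told apart, and nothing at hand accounts for any of these numbers.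

On these data alone, it remains open whether 2-fluorophenyl or 3-chlorophenyl would stay level with compound 3 and compound 4, and where plain phenyl would fall relative to them. Also open, as far as these compounds go, is whether a phenyl ring carrying a methoxy group, an amine or a carboxylic acid would move the number clearly away from those of compound 2, compound 3 and compound 4, and in which direction.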